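This account rests on a few compounds, and the source may have more. Where it says the series, first, only, none or still open, it means among the compounds named here.

Of the compounds shown here, three sharing one core have been measured in a functional assay on isolated protein for inhibition of Glucose-dependent insulinotropic receptor (Rattus norvegicus), read by HTRF and cAMP accumulation; on this read-out lower numbers stand for an effect already at smaller amounts and higher numbers for an effect only at larger amounts of compound. Compound 1 `Cc1nc(S(C)(=O)=O)ccc1Oc1ncnc(OC2CCN(C(=O)OC(C)F)CC2)c1F` gives 315 nM in this assay, compound 2 `CCC1(OC(=O)N2CCC(Oc3ncnc(Oc4ccc(S(C)(=O)=O)nc4C)c3F)CC2)CC1` gives 333 nM, and compound 3 `Cc1nc(S(C)(=O)=O)ccc1Oc1ncnc(OC2CCN(C(=O)C(F)(F)F)CC2)c1F` gives 880 nM. Among these three numbers compound 2 holds the second highest: its nearest neighbour is compound 1, with a 1.1-fold higher number from compound 1 to compound 2 (0.02 log units; within the scatter), and its furthest is compound 3, with a 2.6-fold higher number from compound 2 to compound 3 (0.42 log units; beyond the scatter). A step of the same kind, in which a trifluoromethyl enters on the carbonyl carbon, is a 2.8-fold higher number from compound 1 to compound 3 (0.45 log units; beyond the scatter).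

Compound 4 `Cc1nc(S(C)(=O)=O)ccc1Oc1ncnc(OC2CCN(C(=O)C(C)(C)F)CC2)c1F` has not yet been measured. It differs from compound 2 in one place: a group of 4 heavy atoms (3 carbon, 1 fluorine; no ring) in place of a group of 6 heavy atoms (5 carbon, 1 oxygen; one three-membered non-aromatic ring of carbon only), on a carbonyl carbon. The two measured steps that exchange the group on the carbonyl carbon both raised the number modestly, but there the entering group was trifluoromethyl rather than 1-fluoro-1-methylethyl, so a smaller rise than in those steps seems the likeliest outcome, and one that may not reach beyond the scatter. For compound 4 the expected step is a 1.8-fold higher number from compound 2 to compound 4 (0.26 log units; within the scatter) in this assay. Compound 4 is therefore estimated at 600 nM in this assay, with a range from 300 nM to 1200 nM.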

Compound 4, half-maximal effective concentration: 296 nM
Compound 4: the middle estimate sits 2.0-fold (0.31 log units) above what was measured; the whole stated range lies above it.
By their numbers in this assay, from the lowest: compounds 4, 1 and 2 (each within the scatter of the next); then compound 3.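

In this assay, within the data shown here, compound 3 had been the only compound whose carbonyl carbon carried a group without oxygen, so its higher number might have been tied to that absence; 1-fluoro-1-methylethyl also lacks oxygen, yet it gives a 1.1-fold lower number from compound 2 to compound 4 (0.05 log units; within the scatter) and a 1.1-fold lower number from compound 1 to compound 4 (0.03 log units; within the scatter), both within the scatter. At this position, then, a group without oxygen can match the two oxygen-bearing groups, and the absence of oxygen alone does not go with a higher number. The direct exchange of trifluoromethyl for 1-fluoro-1-methylethyl gives a 3.0-fold lower number from compound 3 to compound 4 (0.47 log units; beyond the scatter), which places the difference between these two fluorine-bearing groups, although no measurement here explains the change.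

The compounds shown leave open whether fluorine matters in the entering group, since every group without oxygen here carries it, and a tert-butyl group on the carbonyl carbon would test this directly. They also leave open how an amine on that carbonyl carbon would compare, as all four compounds have either an oxygen-linked group or a carbon-linked group there.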